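A few compounds are considered here, and "the series" means these few. Any claim that something is new, unique, unknown or untested is made for them only; others in the source may bear on it.

The study measured cytotoxicity in a functional assay on MDA-MB-231 cells (Homo sapiens) for cytotoxicity, read by MTT assay, with a stated time of 72 h; a lower number here means a stronger inhibitor, a higher number a weaker inhibitor. Within the data shown here, compound 2 `COc1ccc(/C=C2\S/C(=N\c3csc(-c4ccc(Cl)cc4)c3)NC2=O)cc1` gives 1200 nM in this assay, and this is the only plain number reported. The other two entries are not plain numbers: one is given differently and one has no result at all. Compound 1 `Cc1ccc(-c2cc(/N=C3/NC(=O)CS3)cs2)cc1` sits at > 50000 nM in this assay, which is a limit of the assay and not a number, as recorded in the limit of > 50000 nM in this assay, at which 1 of the 3 values shown sits. For compound 3 `CCCCCC/C=C1\S/C(=N\c2csc(-c3ccc(Cl)cc3)c2)NC1=O` the entry in this assay reads "not determined" (no result reported), so no value is available. Compound 4 `COc1ccc(/C=C2\S/C(=N\c3csc(-c4ccc(Cl)cc4)c3)NC2=O)cc1OC` has not yet been tested in this assay. It differs from compound 2 by methoxy in place of hydrogen on an aromatic carbon; cut one bond further out, the change reads 4-methoxyphenyl to 3,4-dimethoxyphenyl. Among the measured compounds shown here, no step between two measured compounds is available, so the size of this change in this assay cannot be read from the data, and the author expects a shift no larger than the usual scatter, in either direction. Compound 4 is therefore estimated at 1100 nM in this assay, with a range from 400 nM to 3000 nM and an expected step of a 1.1-fold lower number from compound 2 to compound 4 (0.04 log units; within the scatter).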

Compound 4, half-maximal inhibitory concentration: 1900 nM
Estimate against measurement, compound 4: 1.7-fold (0.24 log units) below, within the range that was stated.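

Among these compounds, the change from 4-methoxyphenyl to 3,4-dimethoxyphenyl gives a 1.6-fold higher number from compound 2 to compound 4 (0.20 log units; within the scatter) in this assay, the first step that can be read, and it shows that this position, ortho to a methoxy group and meta to a large group, takes a second methoxy without a shift beyond the scatter. Compound 2 and compound 4 therefore cannot be put in an order, and the result speaks only for this one group at this one place. Nothing at hand offers a reason for this step. As far as these compounds go, whether a hydroxyl, an amine or a longer chain at the same place would move the number beyond the scatter stays open. Among the compounds shown here, no step to compound 1 or compound 3 can be read, so the role of the other parts of the structure stays open as well.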